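A few compounds are considered here, and "the series" means these few. Any claim that something is new, unique, unknown or untested is made for them only; others in the source may bear on it.

Measured compounds in an assay on CHO cells for binding affinity to corticotropin-releasing factor receptor 1 (Homo sapiens); on this read-out higher numbers stand for weaker inhibition and lower numbers for stronger inhibition:
- compound 1, `CCCN(CC1CC1)c1nc(-c2ccc(Cl)cc2Cl)n(C)n1`: > 10000 nM
- compound 2, `CCCN(c1nc(-c2ccc(Br)cc2C)n(C)n1)C(C1CC1)C1CC1`: 10 nM
- compound 3, `CCCN(c1nc(-c2ccc(Cl)cc2Cl)n(C)n1)c1ccccc1OC`: 3400 nM

The value of compound 1 in this assay is a limit of the assay, not a number. Of the two numbers shown, compound 3 has the higher one and compound 2 the lower one; compound 2 differs from compound 3 at more than one place, so its number gives no single step to compare.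

Compound 4, `CCCN(CCC)c1nc(-c2ccc(Cl)cc2Cl)n(C)n1`, has not been measured. It differs from compound 3 by propyl in place of 2-methoxyphenyl on a nitrogen on an aromatic ring.

Among the compounds with values here, the only measured step on this nitrogen is an at least 2.9-fold lower number from compound 1 to compound 3 (0.46 log units; beyond the scatter), where the 2-methoxyphenyl entered in place of a small alkyl group and the number went down. Compound 4 reverses that direction, putting a small alkyl chain back where compound 1 also carries one, and compound 1 sits at the limit of > 10000 nM in this assay, at which 1 of the 3 values shown sits. The step of a 2.9-fold higher number from compound 3 to compound 4 (0.47 log units; beyond the scatter) is therefore expected to be upward, with a real chance that only a limit is reported. Compound 4 is estimated at 10000 nM, in the range 3000 nM to 30000 nM.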

Compound 4, inhibition constant: 2600 nM
Compound 4: middle estimate off by 3.8-fold (0.59 log units), on the high side; the whole stated range lies above it.
By their numbers in this assay, from the lowest: compound 2; then compounds 4 and 3 (each within the scatter of the next). At a limit, above all of these: compound 1.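

In this assay this nitrogen gives no sign of needing an aromatic ring: a 1.3-fold lower number from compound 3 to compound 4 (0.12 log units; within the scatter), so 2-methoxyphenyl and propyl cannot be told apart here. A chain alone also gives an at least 3.8-fold lower number from compound 1 to compound 4 (0.58 log units; beyond the scatter), with ethyl in place of cyclopropyl on a saturated chain carbon bound to the nitrogen, so the change that separates compound 1 from compound 4 lies at the end of the chain. Compound 1 remains a limit of the assay, not a number, and the size of this step is only a bound: the limit of > 10000 nM in this assay, at which 1 of the 4 values shown sits.

From the compounds shown here alone, whether a longer chain such as butyl, or a chain carrying an ether such as methoxyethyl, would shift the number on this nitrogen stays open. Also open, going by these compounds, is how much of the lower number of compound 2 belongs to its branched dicyclopropylmethyl group, as compound 2 differs from the others at more than one place.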